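A urea substituent swap in a weakly antiproliferative pair

This account rests on a few compounds, and the source may have more. Where it says the series, first, only, none or still open, it means among the compounds named here.

Of the compounds shown here, two have been measured in a functional assay on A549 cells (Homo sapiens) for antiproliferative activity, read by MTT assay; on this read-out lower numbers stand for stronger inhibition and higher numbers for weaker inhibition. Compound 1 `O=C(Nc1cccc(CNc2ncnc3ccccc23)c1)Nc1ccccc1Cl` gives 18000 nM in this assay. Compound 2 `COc1cc2ncnc(NCc3cccc(NC(=O)Nc4ccccc4C)c3)c2cc1OC` gives 21400 nM in this assay, the higher of the two numbers, though its gap to compound 1 lies within the usual scatter, so the two cannot be told apart. Both sit far up the scale, meaning only weak inhibition of cell growth.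

Compound 3 `COc1cc2ncnc(NCc3cccc(NC(=O)Nc4ccc([N+](=O)[O-])cc4)c3)c2cc1OC` is not yet measured. It differs from compound 2 in one place: 4-nitrophenyl in place of 2-methylphenyl on an amide-type nitrogen. The 2-methylphenyl group that leaves and the 4-nitrophenyl group that enters both sit on an amide-type nitrogen whose other neighbour is a carbonyl carbon; the rest of the molecule is unchanged.

Within the data shown here, no measured pair shows what such a swap does here, so the expectation can only rest on compound 2 itself. A step from compound 2 to compound 3 of a 1.4-fold lower number from compound 2 to compound 3 (0.15 log units; within the scatter) is expected, toward slightly stronger inhibition but quite possibly no more than the scatter. Compound 3 is therefore estimated at 15000 nM in this assay, within a range of 5000 nM to 45000 nM.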

Compound 3, half-maximal inhibitory concentration: > 50000 nM
Compound 3 ended at the assay's limit (the forecaster's own chance of this, stated with the estimate: 15%); middle value at least 3.3-fold (0.52 log units) away from the limit.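

Putting 4-nitrophenyl in place of 2-methylphenyl on an amide-type nitrogen gives an at least 2.3-fold higher number from compound 2 to compound 3 (0.36 log units; beyond the scatter) in this assay. Among these compounds, this is the only step between compounds differing in one place, and it lies beyond the scatter, toward weaker inhibition, so the group on this nitrogen does affect the read-out, and this change loses even the weak inhibition seen for compound 2. The step gives only a minimum size, because compound 3 sits at a limit of the assay and not at a number: the limit of > 50000 nM in this assay, at which 1 of the 3 values shown sits.

The swap changes both the substituent and its place on the phenyl ring, so it cannot show which of the two matters; a 4-methylphenyl or a 2-nitrophenyl group on the same nitrogen would separate them. Also open, as far as these compounds go, is whether a different group here, such as 4-aminophenyl or a phenyl ring carrying a carboxylic acid, would give stronger inhibition than compound 2 shows at 21400 nM.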